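This account rests on a few compounds, and the source may have more. Where it says the series, first, only, none or still open, it means among the compounds named here.

Compound 1 `CCCCn1c(-c2ccc(OC)cc2)cnc1NC(=O)c1ccc(F)cc1`: in a toxicity assay on THP-1 cells (Homo sapiens) for inhibition (on this read-out higher numbers stand for lower toxicity in this test and lower numbers for higher toxicity in this test), compound 1 gives > 100000 nM, which is a limit of the assay rather than a number.
Compound 2 `COc1ccc(-c2cnc(NC(=O)c3ccccn3)n2C)cc1`: in this assay compound 2 gives > 100000 nM, again a limit.
Compound 3 `COc1ccc(-c2cnc(NC(=O)CCc3ccccc3)n2C)cc1`: in this assay compound 3 gives > 100000 nM, again a limit.

Compound 3 therefore stands only at a limit, like every other compound here (the limit of > 100000 nM in this assay, at which 3 of the 3 values shown sit). For the measured compounds named here, the one step between measured compounds, a step that the two limits leave unreadable from compound 2 to compound 3, cannot be read because both values sit at that limit. Compound 4 `COc1ccc(-c2cnc(NC(=O)c3cnco3)n2C)cc1` differs from compound 3 by 1,3-oxazol-5-yl in place of phenethyl on a carbonyl carbon. Going by the values given here, no measured step bears on this change, so no shift beyond the scatter is expected in this assay, and compound 4 is estimated to give 150000 nM, within 70000 nM to 400000 nM, a step that the limit leaves unreadable from compound 3 to compound 4.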

Compound 4, half-maximal cytotoxic concentration: > 100000 nM
Compound 4: no number, only a limit (the forecaster's own chance of this, stated with the estimate: 80%); the middle value does not contradict the limit.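

Compound 4 sits at the same limit as compound 2 and compound 3, so neither step to compound 4 can be read: the limit of > 100000 nM in this assay, at which 4 of the 4 values shown sit.

The compounds shown leave open whether changing the group on the carbonyl carbon shifts the result in this assay at all.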